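The source may report more compounds than this note shows. Statements on the series, on what has been measured and on what is new or still open speak of the compounds shown alone.

Three carbamates built on one shared core have been measured in an assay on cell membranes for binding affinity to Fatty-acid amide hydrolase 1 (Rattus norvegicus); on this read-out higher numbers stand for weaker inhibition and lower numbers for stronger inhibition. Compound 1 `Cc1ccc(-c2cccc(OC(=O)NC3CCCCC3)c2)cc1` gives 155 nM. Compound 2 `NC(=O)c1ccc(-c2cccc(OC(=O)NC3CCCCC3)c2)cc1` gives 5910 nM, and the step of a 38-fold higher number from compound 1 to compound 2 (1.58 log units; beyond the scatter) shows that this single swap costs a great deal of binding. Compound 3 `O=C(NC1CCCCC1)Oc1cccc(-c2cccc(F)c2)c1` gives 96.6 nM; the step of a 1.6-fold lower number from compound 1 to compound 3 (0.21 log units; within the scatter) is too small to count as a real change. Compound 3 therefore carries the lowest of the three numbers, yet its gap to compound 1 lies within the scatter, while its gap to compound 2 is wide.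

The next compound, compound 4 `O=C(NC1CCCCC1)Oc1cccc(-c2cccc(Cc3ccccc3)c2)c1`, differs from compound 3 in one place: benzyl in place of fluoro on an aromatic carbon. Among the measured compounds shown here, two measured steps bear on this. The step of a 1.6-fold lower number from compound 1 to compound 3 (0.21 log units; within the scatter) shows that exchanging one hydrocarbon-type substituent for a fluoro on this outer ring barely moved this assay. The step of a 38-fold higher number from compound 1 to compound 2 (1.58 log units; beyond the scatter) shows that a carbamoyl, which carries donors and acceptors, hurt badly; a benzyl carries neither. On that basis a benzyl in place of fluoro is expected to give at most a small shift, in either direction, and the expected step is a 1.3-fold higher number from compound 3 to compound 4 (0.13 log units; within the scatter). Compound 4 is therefore estimated at 130 nM, with a range from 35 nM to 500 nM.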

Compound 4, half-maximal inhibitory concentration: 1860 nM
Estimate against measurement, compound 4: 14-fold (1.16 log units) below; the measured number lies above the stated range.
By their numbers in this assay, from the lowest: compounds 3 and 1 (each within the scatter of the next); then compound 4; then compound 2.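

The step of a 19-fold higher number from compound 3 to compound 4 (1.28 log units; beyond the scatter) in this assay shows that having no hydrogen-bond donors or acceptors does not make a group harmless at this position, meta to a large group on the outer ring. Fluoro and benzyl both have none of either, so the carbamoyl of compound 2 no longer stands alone as a group tied to a large rise in the number. The counts do differ: 7 heavy atoms and a six-membered aromatic ring enter where 1 fluorine atom leaves, but no measurement shown explains why this exchange raises the number.

Going by these compounds, with only fluoro and benzyl compared on this carbon, it remains open whether the number climbs steadily as the group grows or jumps only once a second ring is attached, and a methyl, an ethyl or a phenyl at the same place would help separate these cases. On these data alone, it also remains open how a benzyl with an amine or a carboxylic acid on its ring, or a longer chain ending in a hydroxyl, would read in this assay.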